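Removing One Fluoro from a Pentafluorinated Sulfonamide

This account rests on a few compounds, and the source may have more. Where it says the series, first, only, none or still open, it means among the compounds named here.

Two compounds anchor this small series. In a functional assay on DU-145 cells (Homo sapiens) for cytotoxicity, read by trypan blue exclusion, with a stated time of 96 h (on this read-out lower numbers stand for stronger inhibition and higher numbers for weaker inhibition), compound 1 (`COc1ccc(NS(=O)(=O)/C=C/c2c(F)c(F)c(F)c(F)c2F)cc1F`) gives 10000 nM and compound 2 (`O=S(=O)(/C=C/c1ccc(Br)cc1)Nc1ccc(F)cc1`) gives 10000 nM with no difference between them at the digits reported. Going by the values given here, compound 1 therefore stands level with compound 2, its only measured neighbour, although the two structures differ in more than one place. The next compound to be tested is compound 3 (`COc1ccc(NS(=O)(=O)/C=C/c2c(F)c(F)c(F)c(F)c2F)cc1`), which is built on the core of compound 1 with a single change: hydrogen in place of fluoro on an aromatic carbon puts hydrogen in place of fluoro on an aromatic carbon, ortho to a methoxy group. Among the compounds with values here, no measured pair shows what this change does, so the expectation rests on compound 1 alone, at 10000 nM in this assay as its starting point. With so small a change and no evidence of a direction, no shift beyond the scatter is anticipated, and the estimated step, a 1.3-fold lower number from compound 1 to compound 3 (0.10 log units; within the scatter), would stay within it. Compound 3 is expected at 8000 nM with an estimated range from 1500 nM to 20000 nM in this measurement.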

Compound 3, half-maximal inhibitory concentration: 10000 nM
Compound 3: middle estimate off by 1.3-fold (0.10 log units), on the low side; the measured number falls inside the stated range.
By their numbers in this assay, from the lowest: compounds 1, 2 and 3 (each within the scatter of the next).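

The pair of compound 1 and compound 3 gives this series its first reading of a single change: with hydrogen in place of fluoro on an aromatic carbon, ortho to a methoxy group and meta to a large group, this assay shows no change at the digits printed from compound 1 to compound 3 (within the scatter) for this step. The fluoro at this position is therefore not needed to keep the number where it stands in this read-out, something compound 1 and compound 2 could not show, as they differ in more than one place. No measurement offered here explains why this exchange leaves the number as it is.

This one exchange says nothing yet about whether another group at the same position, such as an amine, a hydroxyl or a trifluoromethyl, would move the number beyond the scatter in this assay. On these data alone, it also remains open what would happen if the methoxy group itself gave way to a longer ether chain or a carboxylic acid, or if the fluoro atoms on the other aromatic ring of the core of compound 1 were exchanged.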